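Compound 3 Gains a Double Bond Outside Aromatic Rings

The compounds below may be only part of what the source reports. "The series", "measured", "known", "first", "only" and "open" are said of these compounds alone.

In a physicochemical assay for acid dissociation, compound 1 `CCCN(C1=NCCN1)c1c(Br)cccc1Br` gives 11, compound 2 `CCCCN(C1=NCCN1)c1c(Br)cccc1Br` gives 11 and compound 3 `CC(C)CN(C1=NCCN1)c1c(Br)cccc1Br` gives 11, which leaves compound 3 level with the other two. Compound 4 `CC(C)=CCN(C1=NCCN1)c1c(Br)cccc1Br` carries 2-methylprop-1-en-1-yl in place of isopropyl on a saturated chain carbon bound to a nitrogen on an aromatic ring. Cut one bond further out, the same difference reads isobutyl to 3-methylbut-2-en-1-yl. The nearest evidence comes from the three measured changes to the saturated chain: no change at the digits printed from compound 1 to compound 2 (within the scatter), no change at the digits printed from compound 1 to compound 3 (within the scatter) and no change at the digits printed from compound 2 to compound 3 (within the scatter). None of these steps introduces a double bond, so the new feature has not been tested directly. Even so, no step beyond the scatter is expected in this assay, and no firm direction can be assigned. The expected step, a number 0.10 log units lower from compound 3 to compound 4 (within the scatter), is therefore small. For compound 4 the estimated value is 10.9, with an expected range from 10.4 to 11.3.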

Compound 4, acid dissociation constant: 10.8
Compound 4: middle estimate off by 0.10 log units, on the high side, and the stated range covers the measured number.
By their numbers in this assay, from the lowest: compounds 4, 1, 2 and 3 (each within the scatter of the next).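

Compound 4 puts a double bond outside aromatic rings at this position, on a saturated chain carbon bound to a nitrogen on an aromatic ring, so this kind of change now has a direct reading in this assay. Set against each saturated chain, 2-methylprop-1-en-1-yl stays within the scatter, with the steps reading (a number 0.20 log units lower from compound 3 to compound 4 (within the scatter)), (a number 0.20 log units lower from compound 2 to compound 4 (within the scatter)) and (a number 0.20 log units lower from compound 1 to compound 4 (within the scatter)). Nothing measured alongside these numbers offers an explanation for them.

Still open, from the compounds shown here alone, is whether a chain ending in an amine or a carboxylic acid at this position would give a step beyond the scatter in this assay. A longer chain carrying the double bond, or a triple bond in its place, also remains to be read.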